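The compounds below may be only part of what the source reports. "The series", "measured", "known", "first", "only" and "open" are said of these compounds alone.

In a functional assay on the whole organism (plasma, strain Sprague-Dawley) with Rattus norvegicus as the target, with a stated time of 2 h, at a dose of 12.5 mg/kg by the oral route (on this read-out lower numbers stand for a weaker effect and higher numbers for a stronger effect at the one dose given), compound 1 `c1ccc(C(/N=C2\CCCCN2)C2CC2)cc1` gives 1% and compound 2 `c1ccc(C(/N=C2\CCCCN2)c2ccco2)cc1` gives 13%. Among the compounds with values here, the single measured step, a number 12 percentage points higher from compound 1 to compound 2 (beyond the scatter), came with furan-2-yl in place of cyclopropyl on a saturated chain carbon bound to an aromatic carbon and a double-bonded nitrogen. Of the two numbers, compound 2 stands highest, with compound 1 the nearest and lower. Compound 3 `c1ccc(C(/N=C2\CCCCN2)c2cccs2)cc1` differs from compound 2 by thiophen-2-yl in place of furan-2-yl on a saturated chain carbon bound to an aromatic carbon and a double-bonded nitrogen. Within the data shown here, no measured step covers thiophen-2-yl in place of furan-2-yl; the only step, to compound 2, was modest and concerned a different exchange. A step within the scatter is therefore expected, a number 2 percentage points higher from compound 2 to compound 3 (within the scatter). Compound 3 is estimated at 15% in this assay, between 3% and 30%.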

Compound 3, a percentage reported as inhibition, in the whole organism at one dose (the size of the read-out at that dose, not a potency): 13%
Beside the measured number, compound 3's estimate is 2 percentage points above it, and the stated range covers the measured number.
By their numbers in this assay, from the lowest: compound 1; then compounds 2 and 3 (each within the scatter of the next).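

Thiophen-2-yl in place of furan-2-yl on a saturated chain carbon bound to an aromatic carbon and a double-bonded nitrogen gives no change at the digits printed from compound 2 to compound 3 (within the scatter) in this assay, so the oxygen-to-sulfur exchange in this ring leaves the read-out within the scatter. With a number 12 percentage points higher from compound 1 to compound 3 (beyond the scatter) for thiophen-2-yl in place of cyclopropyl, the rise over cyclopropyl is not confined to furan-2-yl. No available evidence bears on the reason for either step.

Open: how phenyl, pyridin-2-yl or an n-butyl chain on this carbon would read, and whether changes to the shared core would shift the read-out.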